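Amide Variation on a Shared Core Ahead of Compound 4

The source may report more compounds than this note shows. Statements on the series, on what has been measured and on what is new or still open speak of the compounds shown alone.

Three measured compounds share one core. Compound 1 `COc1cc2c(cc1OC)C(CC(=O)O)CC2` gives 24% in a functional assay on the whole organism (strain Wistar) for inhibition, with Rattus norvegicus as the target, read by paw edema, with stated times of 60 min and 2 h, at a dose of 100 mg/kg by the oral route; on this read-out higher numbers stand for more inhibition at the one dose given (going by the name of the read-out) and lower numbers for less inhibition. Compound 2 `CCCCNC(=O)CC1CCc2cc(OC)c(OC)cc21` gives 24% there, and compound 3 `COc1cc2c(cc1OC)C(CC(=O)NCc1ccccc1)CC2` gives 24%. Each step alters only the group on the carbonyl carbon: no change at the digits printed from compound 1 to compound 2 (within the scatter), no change at the digits printed from compound 1 to compound 3 (within the scatter) and no change at the digits printed from compound 2 to compound 3 (within the scatter). Compound 2 thus stands level with compound 1 and compound 3 in this assay. Compound 4 `COc1cc2c(cc1OC)C(CC(=O)N1CCNCC1)CC2` has not yet been measured; it differs from compound 2 by piperazin-1-yl in place of butylamino on a carbonyl carbon. With all three carbonyl-carbon steps lying within the scatter, the expected step is no change at the digits printed from compound 2 to compound 4 (within the scatter), no movement beyond the scatter in either direction. Compound 4 is accordingly estimated at 24%, with a range from 12% to 36%.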

Compound 4, a percentage reported as inhibition, in the whole organism at one dose (the size of the read-out at that dose, not a potency): 44%
Estimate against measurement, compound 4: 20 percentage points below; the measured number lies above the stated range.
By their numbers in this assay, from the lowest: compounds 1, 2 and 3 (each within the scatter of the next); then compound 4.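

In this assay, the group on the carbonyl carbon, which had shown no effect among the earlier compounds, now makes a difference: piperazin-1-yl gives a number 20 percentage points higher from compound 2 to compound 4 (beyond the scatter), a number 20 percentage points higher from compound 3 to compound 4 (beyond the scatter) and a number 20 percentage points higher from compound 1 to compound 4 (beyond the scatter). Of the four groups shown at this place, only piperazin-1-yl stands apart, while hydroxy, butylamino and benzylamino remain level. Nothing available here explains this rise. The compounds shown leave open whether the step goes with the ring or with its second nitrogen. A piperidin-1-yl or morpholin-4-yl amide would help separate the two.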